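A few compounds are considered here, and "the series" means these few. Any claim that something is new, unique, unknown or untested is made for them only; others in the source may bear on it.

Measured in an ADME assay on HEK293 cells (Homo sapiens) for cytotoxicity, read by resazurin assay, with a stated time of 48 h; a lower number here means that less compound is tolerated, a higher number that more compound is tolerated:
- compound 1 `O=S(=O)(Nc1ccc(-c2nc3ccccc3o2)cc1)c1ccc(Cl)c(C(F)(F)F)c1`: 69000 nM
- compound 2 `Cc1ccc(S(=O)(=O)Nc2ccc(-c3nc4ccccc4o3)cc2)cc1`: 88000 nM
- compound 3 `Cc1ccc(S(=O)(=O)Nc2ccc3oc(-c4ccccc4)nc3c2)cc1`: 75000 nM

Compound 2 sits close to the other two measured compounds. With 88000 nM, compound 2 lies within the usual scatter of repeated measurements of both compound 3 and compound 1, so these numbers cannot be ranked. Among the measured compounds shown here, no two measured compounds differ in just one place, which means the data offer no direct example of what a single change does here.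

The next compound, compound 4 `CS(=O)(=O)Nc1ccc(-c2nc3ccccc3o2)cc1`, keeps the rest of compound 2 and changes one group: methyl in place of 4-methylphenyl on a sulfonyl sulfur. For the measured compounds named here, none of the measured compounds carries such a small group there, so this prediction reaches beyond what has been tested. Going by the values given here, the only guide is the close grouping of compound 1 at 69000 nM, compound 2 at 88000 nM and compound 3 at 75000 nM. On that basis, only a slight lean towards more compound being tolerated is expected in this assay, with no step beyond the scatter. The estimated change is small: a 1.1-fold higher number from compound 2 to compound 4 (0.06 log units; within the scatter). The expected value for compound 4 is 100000 nM, with an estimated range from 55000 nM to 200000 nM.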

Compound 4, half-maximal cytotoxic concentration: > 100000 nM
Compound 4 gave a limit, no number (the forecaster's own chance of this, stated with the estimate: 35%); the middle value lies on the limit itself.
By their numbers in this assay, from the lowest: compounds 1, 3 and 2 (each within the scatter of the next). At a limit, above all of these: compound 4.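

In this assay, compound 4 gives > 100000 nM, which is a limit of the assay and not a number. This is the first pair shown that differs in only one place, and putting methyl in place of 4-methylphenyl on a sulfonyl sulfur gives an at least 1.1-fold higher number from compound 2 to compound 4 (0.05 log units; that floor lies within the scatter). So the six-membered aromatic ring can leave this position without any sign of a lower number in this assay, although the true size of the step cannot be read and the comparison rests on a single compound at the top of the range: the limit of > 100000 nM in this assay, at which 1 of the 4 values shown sits.

The compounds shown leave open what a group of another kind would do on the same sulfonyl sulfur, such as a longer chain or a carbon chain ending in an amine, and whether any such group would bring a step beyond the scatter. Among the compounds shown here, they also leave open whether the same change would give a similar result on the core of compound 3, since this single pair is the only example of it.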